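Series notes: the same ring swap on a second core

The source may hold more compounds than are shown below. What is called first, only, known or untested is meant among the compounds shown, and "the series" means these compounds.

Compound 1 `O=C(N/N=C/c1cccnc1)c1cccnc1Nc1cccc(C(F)(F)F)c1` and compound 2 `O=C(N/N=C/c1ccncc1)c1cccnc1Nc1cccc(C(F)(F)F)c1` share one core; compound 3 `CNc1ncccc1C(=O)N/N=C/c1cccnc1` and compound 4 `CNc1ncccc1C(=O)N/N=C/c1ccncc1` share another, and the difference between the two cores is not broken down here. In a functional assay on the whole organism (strain Wistar) for inhibition, with Rattus norvegicus as the target, read by paw edema, with a stated time of 3 h, at a dose of 10 mg/kg by the intraperitoneal route (on this read-out lower numbers stand for less inhibition and higher numbers for more inhibition at the one dose given (going by the name of the read-out)), compound 1 gives 52.4% and compound 2 gives 54.9%. The change between them is pyridin-4-yl in place of pyridin-3-yl on a carbon with a double bond to nitrogen and it produced a number 2.5 percentage points higher from compound 1 to compound 2 (within the scatter). In this assay compound 3 gives 27.7%, the lowest of the three numbers and beyond the scatter from both of the others. Compound 4 carries the same change on the core of compound 3: pyridin-4-yl in place of pyridin-3-yl on a carbon with a double bond to nitrogen. Because a number 2.5 percentage points higher from compound 1 to compound 2 (within the scatter) lay within the scatter, the step from compound 3 to compound 4 is expected to be a number 2.3 percentage points higher from compound 3 to compound 4 (within the scatter). Compound 4 is accordingly estimated at 30% in this assay.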

Compound 4, a percentage reported as inhibition, in the whole organism at one dose (the size of the read-out at that dose, not a potency): 55%
The estimate for compound 4 lay 25 percentage points below the measured number; measured number above the stated range.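

In this assay, pyridin-4-yl in place of pyridin-3-yl gives a number 27.3 percentage points higher from compound 3 to compound 4 (beyond the scatter), and this does not match the same change on the other core: the same change on two cores in this assay, a number 2.5 percentage points higher (within the scatter) from compound 1 to compound 2 and a number 27.3 percentage points higher (beyond the scatter) from compound 3 to compound 4, 24.8 percentage points apart, beyond the scatter of two such steps. In these two pairs, the size of the step therefore differs with the core, so the step from one core does not predict the step on the other. Among the compounds shown here, with only two cores, and the difference between them not broken down, this does not show which feature of the core matters, and readings at one dose say nothing about potency.

As far as these compounds go, it remains open how pyridin-2-yl on the carbon with a double bond to nitrogen would behave on either core. Also open, from the compounds shown here alone, is whether a core carrying a longer chain on the amine nitrogen would follow the smaller or the larger step.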